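The source may hold more compounds than are shown below. What is called first, only, known or untested is meant among the compounds shown, and "the series" means these compounds.

Working notes on the series. Of the compounds shown here, two have been measured. Compound 1 `COc1cc(OC)c2cc(-c3ccc(OCc4ccccc4)cc3)c(O)nc2c1` gives 10000 nM in a functional assay on A 172 cells (Homo sapiens) for cytotoxicity, read by colorimetric assay and MTT assay; on this read-out lower numbers stand for stronger inhibition and higher numbers for weaker inhibition. Compound 2 `CCOC(=O)Cn1c(=O)c(-c2ccc(OC)cc2)cc2c(OC)cc(OC)cc21` gives 10000 nM in this assay, level with compound 1 at the digits shown and within the usual scatter of this kind of measurement. Within the data shown here, no pair of measured compounds differs in one place only, so no single-point step is available to lean on.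

Compound 3 `CCN(CC)C(=O)CCn1c(=O)c(-c2ccc(OC)cc2)cc2c(OC)cc(OC)cc21` has not yet been measured. It differs from compound 2 in one place: (diethylcarbamoyl)methyl in place of ethoxycarbonyl on a saturated chain carbon bound to an aromatic nitrogen. Nothing measured in the series bears on this particular change, and the two values in hand sit at the same figure, which gives no direction to extrapolate. The step is therefore expected to be none beyond the scatter, and the estimate for it reads no change at the digits printed from compound 2 to compound 3 (within the scatter). Compound 3 is expected to give about 10000 nM in this assay, with a range from 4000 nM to 25000 nM.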

Compound 3, half-maximal inhibitory concentration: 10000 nM
Compound 3: middle estimate and measured number agree at the digits printed, within the range that was stated.
By their numbers in this assay, from the lowest: compounds 1, 2 and 3 (each within the scatter of the next).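

The chain on the aromatic nitrogen now has its first single-place reading: in this assay, putting (diethylcarbamoyl)methyl in place of ethoxycarbonyl on a saturated chain carbon bound to an aromatic nitrogen gives no change at the digits printed from compound 2 to compound 3 (within the scatter), so this exchange does not separate the two compounds on this read-out. The same step can also be read as (ethoxycarbonyl)methyl to 2-(diethylcarbamoyl)ethyl, so it covers both the end group and the chain length together, and the two contributions cannot be read apart. No measurement on hand gives a reason for this result.

Still open, on these data alone, is whether a carboxylic acid or a primary amine at the end of this chain would read differently from compound 2 and compound 3. As far as these compounds go, a 2-(diethylcarbamoyl)methyl-length chain with a morpholine or piperidine amide also remains open.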